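The compounds below may be only part of what the source reports. "The series", "measured", "known", "first", "only" and "open" are said of these compounds alone.

Measured so far in an assay on isolated protein for inhibition of Dihydrofolate reductase (Homo sapiens), read by spectrophotometry, using NADPH, with stated times of 5 s and 6 min, tested at 5 uM; a higher number here means a stronger effect of the compound at the concentration tested, a lower number a weaker effect:

- compound 1 `NC1=NC2(CCSCC2)N(OCCCOc2ccc(Br)cc2)C(N)=N1`: in this assay compound 1 gives > 90%, a limit of the assay and not a number.
- compound 2 `NC1=NC2(CCOCC2)N(OCCCOc2ccc(Cl)cc2Cl)C(N)=N1`: compound 2 gives > 90%, again a limit of the assay.
- compound 3 `NC1=NC2(CCOCC2)N(OCCCOc2cccc(Cl)c2)C(N)=N1`: compound 3 gives 83.2%.

Compound 1 thus stands at the ceiling of what this assay reports; (the limit of > 90% in this assay, at which 2 of the 3 values shown sit), so its true inhibition is known only as lying at or past that limit, and any step away from it can only be read as a fall or as no change.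

Compound 4 `COc1ccc(OCCCON2C(N)=NC(N)=NC23CCSCC3)cc1` is to be measured. It differs from compound 1 in one place: methoxy in place of bromo on an aromatic carbon.

Going by the values given here, the only measured step that touches the aryl group on the oxygen on a saturated carbon is a number at least 6.8 percentage points lower from compound 2 to compound 3 (that floor lies within the scatter). Among the compounds with values here, that change is not the same as the one from compound 1 to compound 4, but it shows that altering the substitution of that ring leaves the read-out close to the ceiling. On this basis compound 4 is expected to stay high, with a step of a number at least 5 percentage points lower from compound 1 to compound 4 (that floor lies within the scatter) that is expected to be small and at most a modest fall, not beyond the scatter with confidence.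

Estimate for compound 4 in this assay: 85%, expected to fall between 65% and 95%.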

Compound 4, a percentage reported as inhibition, at one concentration (the size of the read-out at that concentration, not a potency): 81.3%
Compound 4: middle estimate off by 3.7 percentage points, on the high side; the measured number falls inside the stated range.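

In this assay, going by these compounds alone, the change from bromo to methoxy, para to a large group on the aromatic ring, is read as a number at least 8.7 percentage points lower from compound 1 to compound 4 (that floor lies within the scatter), the first step at this position with the core of compound 1 kept. With methoxy in this place, compound 4 gives 81.3%, a measured number rather than a limit, so this series now holds a 4-methoxyphenyl member whose read-out can be used as a reference for further changes at this position. Compound 1 is held only as a limit of the assay, so the true size of the step stays unknown and it may be larger than its floor, which is why no fall beyond the scatter can be claimed or excluded: the limit of > 90% in this assay, at which 2 of the 4 values shown sit.

The compounds shown leave open how the read-out responds when this position carries an amine, a carboxylic acid or a nitrile, since only bromo and methoxy stand here on this core. Also open, as far as these compounds go, is whether a longer chain between the aromatic ring and the core would alter the read-out, and how far a member with bromo at this position lies past the limit.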